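This account rests on a few compounds, and the source may have more. Where it says the series, first, only, none or still open, it means among the compounds named here.

Values in an in vitro ADME assay on microsomes from Gut (Homo sapiens) for metabolic stability, using NADPH; a higher number here means faster removal of the compound, a lower number slower removal:

- compound 1 `COc1ccc(OC(F)(F)F)cc1Cn1c(C(=O)NCC(C)(C)CO)cc2cc(C#N)ccc21`: < 6 mL.min-1.g-1 (a limit)
- compound 2 `COc1ccc(Cl)cc1Cn1c(C(=O)NCC(C)(C)CO)cc2cc(C#N)ccc21`: < 6 mL.min-1.g-1 (a limit)
- compound 3 `Cc1ccc(C(F)(F)F)cc1Cn1c(C(=O)NCC(C)(C)CO)cc2cc(C#N)ccc21`: < 6 mL.min-1.g-1 (a limit)

Compound 2 stands at < 6 mL.min-1.g-1, which is a limit of the assay and not a number. The values for compound 1 and compound 3 are limits as well, so compound 2 cannot be ranked against either.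

Compound 4 `CCCOc1cccc(Cn2c(C(=O)NCC(C)(C)CO)cc3cc(C#N)ccc32)c1` has not yet been measured in this assay. Its change from compound 2 is 3-propoxyphenyl in place of 5-chloro-2-methoxyphenyl on a saturated chain carbon bound to an aromatic nitrogen. The 3-propoxyphenyl thus enters on the same saturated chain carbon bound to an aromatic nitrogen, and the rest of the structure stays the same.

Among the measured compounds shown here, the one measured step between neighbours, a step that the two limits leave unreadable from compound 1 to compound 2, gives no size to carry over, and it concerns a different change. For the measured compounds named here, the only other guide is the limit of < 6 mL.min-1.g-1 in this assay, at which 3 of the 3 values shown sit. Going by the values given here, no measured compound carries the 3-propoxyphenyl, so this is a weak basis for any forecast. As far as these compounds go, no step beyond the scatter is therefore expected, although an upward move toward faster removal remains open, and the expected step is a number no lower from compound 2 to compound 4 (the limit leaves the size open).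

For compound 4 the estimated value is 6 mL.min-1.g-1, with an expected range from 3 mL.min-1.g-1 to 15 mL.min-1.g-1.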

Compound 4, intrinsic clearance in microsomes: 13 mL.min-1.g-1
Estimate against measurement, compound 4: 2.2-fold (0.34 log units) below; measured number inside the range.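

In this assay, the group on the saturated chain carbon bound to an aromatic nitrogen can produce a readable difference: 3-propoxyphenyl in place of 5-chloro-2-methoxyphenyl gives an at least 2.1-fold higher number from compound 2 to compound 4 (0.33 log units; beyond the scatter). Compound 4 is the only compound shown with a number rather than a limit, which separates it from the rest of the set: the limit of < 6 mL.min-1.g-1 in this assay, at which 3 of the 4 values shown sit. The steps among the three compounds at the limit cannot be read, so this step alone gives a size in the series, and that size is a floor, with the true gap from compound 2 left open.

The swap replaces the whole group at once, so the compounds shown do not separate the arrival of the propoxy chain from the loss of the chloro and methoxy substituents, and they do not show how much of the step depends on where the chain sits on the phenyl. Also open, as far as these compounds go, is how a shorter ethoxy chain, a longer butoxy chain, or an amine at the end of the chain would stand in this assay.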